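This account rests on a few compounds, and the source may have more. Where it says the series, first, only, none or still open, it means among the compounds named here.

Compound 1 `C=C[C@@](C)(/C=C/c1ccc(Nc2ccccc2)cc1)CCC=C(C)C` gives in a functional assay on SEM cells (Homo sapiens) for cytotoxicity, with a stated time of 72 h; a lower number here means that less compound is needed, a higher number that more compound is needed for the effect > 36600 nM, which is a limit of the assay and not a number. Compound 2 `C=C[C@@](C)(/C=C/c1ccc(Nc2cc(F)c(F)cc2F)cc1)CCC=C(C)C` gives in this assay > 36600 nM, likewise a limit. Compound 3 `C=C[C@@](C)(/C=C/c1ccc(Nc2cccc(C(F)(F)F)c2)cc1)CCC=C(C)C` gives in this assay > 36600 nM, again a limit. The step that the two limits leave unreadable from compound 1 to compound 2 and the step that the two limits leave unreadable from compound 1 to compound 3 stay unreadable because of the limit of > 36600 nM in this assay, at which 3 of the 3 values shown sit. Compound 4 `C=C[C@@](C)(/C=C/c1ccc(-c2ccc(F)cc2)cc1)CCC=C(C)C` differs from compound 1 by 4-fluorophenyl in place of anilino on an aromatic carbon. Among the measured compounds shown here, no measured step bears on this change; all variation so far sits on the anilino nitrogen and its ring, and none of it moves off the limit. Expected is therefore a step that the limit leaves unreadable from compound 1 to compound 4 that stays within the scatter. The estimate for compound 4 in this assay is 50000 nM, within 20000 nM to 150000 nM, most probably reported only as a limit.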

Compound 4, half-maximal effective concentration: > 36600 nM
Compound 4 was reported as a limit; the forecaster's own chance of this, stated with the estimate: 80%; the middle value does not contradict the limit.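

Compound 4 adds no readable step against compound 1, because both stand at a limit and not a number: the limit of > 36600 nM in this assay, at which 4 of the 4 values shown sit.
In this assay the compounds shown leave open which change to the shared core, if any, would give a measured number.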